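Compound 3 to compound 4: a substituted acrylamide

This account rests on a few compounds, and the source may have more. Where it says the series, first, only, none or still open, it means among the compounds named here.

Measured in a functional assay on HeLa cells (Homo sapiens) for antiproliferative activity, read by MTT assay, with a stated time of 72 h; on this read-out lower numbers stand for stronger inhibition and higher numbers for weaker inhibition:
- compound 1 `CC(C)=CC(=O)Nc1cccc(Oc2nc(Nc3ccn(C)n3)nc3c2CSCC3)c1`: > 50000 nM (a limit of the assay, not a number)
- compound 2 `C=CC(=O)Nc1cccc(Oc2nc(Nc3cccc(OC)c3)nc3c2CSCC3)c1`: 28900 nM
- compound 3 `C=CC(=O)Nc1cccc(Oc2nc(Nc3ccc(OC)cc3)nc3c2CSCC3)c1`: 20900 nM

Compound 3, at 20900 nM, cannot be separated from compound 2, at 28900 nM, in this assay. Going by the values given here, the one measured step, a 1.4-fold lower number from compound 2 to compound 3 (0.14 log units; within the scatter), leaves the two together. The only other entry is a limit.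

Compound 4 `COc1ccc(Nc2nc3c(c(Oc4cccc(NC(=O)C=C(C)C)c4)n2)CSCC3)cc1` keeps the 4-methoxyphenyl of compound 3 and has 2-methylprop-1-en-1-yl in place of vinyl on a carbonyl carbon.

Among the compounds with values here, no measured pair isolates this change. The step of a 1.4-fold lower number from compound 2 to compound 3 (0.14 log units; within the scatter) concerns the methoxy group on the other side of the molecule, so it says nothing about the size of this one. Compound 1 also carries 2-methylprop-1-en-1-yl on a carbonyl carbon, and it stands at the limit of > 50000 nM in this assay, at which 1 of the 3 values shown sits. That is a limit only, but it is the sole pointer available, and it points toward higher numbers. A modest move in that direction is therefore expected, with no firm claim that it will clear the scatter.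

The expected change is a 1.7-fold higher number from compound 3 to compound 4 (0.22 log units; within the scatter). For compound 4 the estimated value is 35000 nM, with an expected range of 15000 nM to 50000 nM.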

Compound 4, half-maximal inhibitory concentration: 19100 nM
For compound 4 the middle estimate is 1.8-fold (0.26 log units) above the measured one; the measured number falls inside the stated range.
By their numbers in this assay, from the lowest: compounds 4, 3 and 2 (each within the scatter of the next). At a limit, above all of these: compound 1.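

In this assay, 2-methylprop-1-en-1-yl in place of vinyl on a carbonyl carbon gives a 1.1-fold lower number from compound 3 to compound 4 (0.04 log units; within the scatter), so with 4-methoxyphenyl held constant, this change has no effect that can be separated from the scatter. Going by these compounds alone, the larger difference appears on the other side of the molecule, where 4-methoxyphenyl in place of 1-methyl-1H-pyrazol-3-yl on a nitrogen on an aromatic ring gives an at least 2.6-fold lower number from compound 1 to compound 4 (0.41 log units; beyond the scatter), the first step to lie beyond the scatter. Compound 1 remains a limit of the assay and not a number, which leaves this step without a fixed size: the limit of > 50000 nM in this assay, at which 1 of the 4 values shown sits.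

The compounds shown leave open whether vinyl and 2-methylprop-1-en-1-yl would also stay together with 1-methyl-1H-pyrazol-3-yl on that nitrogen, so the result for this change rests on a single pair. They also leave open how ethyl, which has no double bond, or a chain ending in a dimethylamine would read in place of vinyl on the same carbonyl carbon.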